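Swapping bis(cyclopropylmethyl)amino for (4-hydroxybenzyl)amino

A few compounds are considered here, and "the series" means these few. Any claim that something is new, unique, unknown or untested is made for them only; others in the source may bear on it.

In an ADME assay on A549 cells (Homo sapiens) for cytotoxicity, read by resazurin assay, with a stated time of 48 h (a higher number here means that more compound is tolerated, a lower number that less compound is tolerated), compound 1 (`CCCN(CCC)c1ccc(NC(=O)c2cc(Cl)ccc2O)c(Cl)c1`) gives 10700 nM and compound 2 (`O=C(Nc1ccc(N(CC2CC2)CC2CC2)cc1Cl)c1cc(Cl)ccc1O`) gives 12800 nM with the two level within the scatter. Compound 3 (`O=C(Nc1ccc(NCc2ccc(O)cc2)cc1Cl)c1cc(Cl)ccc1O`) has (4-hydroxybenzyl)amino in place of bis(cyclopropylmethyl)amino on an aromatic carbon. Going by the values given here, the one measured step (a 1.2-fold higher number from compound 1 to compound 2 (0.08 log units; within the scatter)) exchanges dipropylamino for bis(cyclopropylmethyl)amino and does not cover a change of this kind. It offers no ground for a shift beyond the scatter in this assay and none is expected, though the uncertainty is wide. The estimated step (a 1.3-fold lower number from compound 2 to compound 3 (0.11 log units; within the scatter)) is therefore small. Compound 3 is expected at 10000 nM with an estimated range of 3000 nM to 30000 nM around that figure.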

Compound 3, half-maximal cytotoxic concentration: 116000 nM
Compound 3: middle estimate off by 12-fold (1.06 log units), on the low side; the whole stated range lies below it.
By their numbers in this assay, from the lowest: compounds 1 and 2 (each within the scatter of the next); then compound 3.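

In this assay the group at this position does move the number: a 9.1-fold higher number from compound 2 to compound 3 (0.96 log units; beyond the scatter), and likewise an 11-fold higher number from compound 1 to compound 3 (1.04 log units; beyond the scatter), whereas exchanging dipropylamino for bis(cyclopropylmethyl)amino stayed within the scatter. Both steps bring in (4-hydroxybenzyl)amino, which carries an aromatic ring and hydrogen-bond donors, and more compound is tolerated with it than with either dialkylamino group. Nothing available bears on the cause of this rise. Still open, on these data alone, is which part of the entering group carries the step. Plain benzylamino or 4-methoxybenzylamino at this position would separate the hydroxyl from the ring.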